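Replacing hydroxy with dimethylamino in compound 2

The compounds below may be only part of what the source reports. "The series", "measured", "known", "first", "only" and "open" are said of these compounds alone.

Among the compounds with values here, in a functional assay on HeLa cells (Homo sapiens) for cytotoxicity, read by CCK-8 assay (a lower number here means a stronger inhibitor, a higher number a weaker inhibitor), compound 2 (`O=C(Nc1ccc(O)cc1)c1ncc(-c2ccccc2)o1`) gives 780 nM as the only actual number so far. Compound 1 (`O=C(Nc1ccc(O)cc1)c1ncc(-c2ccc(F)cc2)o1`) reads > 30000 nM as a limit. Compound 3 (`COc1ccc(NC(=O)c2ncc(-c3ccccc3)o2)cc1`) also reads > 30000 nM as a limit. Both measured steps therefore end on the limit of > 30000 nM in this assay, at which 2 of the 3 values shown sit, and give only a minimum size.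

Compound 4 (`CN(C)c1ccc(NC(=O)c2ncc(-c3ccccc3)o2)cc1`) carries dimethylamino in place of hydroxy on an aromatic carbon, para to a large group (dimethylamino in place of hydroxy on an aromatic carbon). The step that bears most on this is an at least 38-fold higher number from compound 2 to compound 3 (1.58 log units; beyond the scatter) which is large and beyond the scatter, and which also changes the hydroxy group, with methyl in place of hydrogen on the oxygen. The step of an at least 38-fold lower number from compound 1 to compound 2 (1.58 log units; beyond the scatter) is equally large but concerns hydrogen in place of fluoro, a different change, so it bears only indirectly.

On that precedent, a large move to a higher number is expected, estimated as a 19-fold higher number from compound 2 to compound 4 (1.28 log units; beyond the scatter) and possibly ending at the limit. For compound 4 the estimate is 15000 nM with 3000 nM to 30000 nM as the expected range.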

Compound 4, half-maximal inhibitory concentration: > 30000 nM
Compound 4 ended at the assay's limit; the forecaster's own chance of this, stated with the estimate: 60%; at least 2.0-fold (0.30 log units) between middle value and limit.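

In this assay dimethylamino in place of hydroxy gives an at least 38-fold higher number from compound 2 to compound 4 (1.58 log units; beyond the scatter) as a second replacement at this position, and here the oxygen itself leaves, along with the 1 hydrogen-bond donor of the hydroxy. Of the groups shown at this position, only the hydroxy of compound 2 gives an actual number, although compound 1 keeps the hydroxy and also sits at the assay's limit, so the hydroxy alone does not secure a measurable value. The step from compound 3 to compound 4 cannot be read, and methoxy and dimethylamino cannot be ranked: the limit of > 30000 nM in this assay, at which 3 of the 4 values shown sit.

An amino group, with hydrogens on the nitrogen, or a carboxylic acid at this position would show whether other groups keep a measurable value. As far as these compounds go, whether anything other than hydroxy does so remains open.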